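A smaller aromatic group on the amide carbonyl

The source may hold more compounds than are shown below. What is called first, only, known or untested is meant among the compounds shown, and "the series" means these compounds.

Compound 1 `CCCCCCCCCCC(C)(C)NC(=O)c1c(OC)cc(OC)cc1OC` was tested in an assay on microsomes from liver for inhibition of sterol O-acyltransferase 1 (Rattus norvegicus); a higher number here means a weaker inhibitor, a lower number a stronger inhibitor; for compound 1 only a limit is recorded, namely > 10000 nM. Compound 2 `CCCCCCCCCCCCn1nnc(C(NC(=O)c2c(C(C)C)cccc2C(C)C)c2ccccc2)n1` gives 810 nM in this assay, which is the highest of the two plain numbers shown. Compound 3 `CCCCCCCCCCCCn1nnc(C(NC(=O)c2ccccc2)c2ccccc2)n1` gives 350 nM in this assay. For the measured compounds named here, the single measured step between neighbours is a 2.3-fold lower number from compound 2 to compound 3 (0.36 log units; beyond the scatter), a change confined to the group on the carbonyl carbon.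

Compound 4 `CCCCCCCCCCCCn1nnc(C(NC(=O)c2ccc(OC)cc2)c2ccccc2)n1` has not yet been measured. It differs from compound 2 in one place: 4-methoxyphenyl in place of 2,6-diisopropylphenyl on a carbonyl carbon. The step from compound 2 to compound 3 bears directly on this, since it too swaps the 2,6-diisopropylphenyl on the carbonyl carbon for a single aromatic ring, and that step was modest but beyond the scatter. A change of similar size and direction is expected here, a 1.8-fold lower number from compound 2 to compound 4 (0.26 log units; within the scatter). Compound 4 is therefore estimated to give about 450 nM in this assay, with a likely range from 150 nM to 1400 nM.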

Compound 4, half-maximal inhibitory concentration: 600 nM
For compound 4 the middle estimate is 1.3-fold (0.12 log units) below the measured one; low and high end bracket the measured number.
By their numbers in this assay, from the lowest: compounds 3, 4 and 2 (each within the scatter of the next, the first and the last beyond it). At a limit, above all of these: compound 1.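

In this assay the swap of 2,6-diisopropylphenyl for 4-methoxyphenyl on the carbonyl carbon gives a 1.4-fold lower number from compound 2 to compound 4 (0.13 log units; within the scatter) and so cannot be told apart from repeat measurement. Methoxy in place of hydrogen on an aromatic carbon gives a 1.7-fold higher number from compound 3 to compound 4 (0.23 log units; within the scatter) and is equally unresolved, so this position tolerates the methoxy group without a clear change in either comparison. For the compounds shown here, the earlier 2.3-fold lower number from compound 2 to compound 3 (0.36 log units; beyond the scatter) remains the only step here beyond the scatter, and compound 4 cannot be assigned to either end of it.

From the compounds shown here alone, whether another group on this ring, such as an amine or a carboxylic acid, would shift the number beyond the scatter remains open. Nothing shown here bears on why these numbers fall as they do.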